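The compounds below may be only part of what the source reports. "The series", "measured", "known", "first", "only" and "open" are said of these compounds alone.

Within the data shown here, compound 1 `COc1cc(/C=C/C(=O)c2cccc(-n3cc(-c4ccc(Cl)cc4)[nH]c3=O)c2)ccc1O` was tested in a functional assay on NCI/ADR-RES cells (Homo sapiens) for inhibition (on this read-out lower numbers stand for stronger inhibition of growth and higher numbers for weaker inhibition of growth), and gave 2280 nM, the higher of the two numbers known so far. Compound 2 `COc1cc(/C=C/C(=O)c2cccc(-n3cc(-c4ccccc4)[nH]c3=O)c2)cc(OC)c1OC` gave 1100 nM in this assay, a lower number that lies beyond the usual scatter. Compound 3 `COc1cc(/C=C/C(=O)c2cccc(-n3cc(-c4ccccc4)[nH]c3=O)c2)ccc1O` has not yet been measured; it differs from compound 1 in one place: hydrogen in place of chloro on an aromatic carbon. Among the measured compounds shown here, no step between measured compounds shows what this change does, so compound 3 is expected to move only within the scatter, giving a 1.2-fold higher number from compound 1 to compound 3 (0.07 log units; within the scatter) from compound 1. Compound 3 is therefore estimated at 2700 nM, between 1100 nM and 6500 nM.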

Compound 3, concentration for 50% growth inhibition: 2920 nM
Compound 3: middle estimate off by 1.1-fold (0.03 log units), on the low side, within the range that was stated.
By their numbers in this assay, from the lowest: compound 2; then compounds 1 and 3 (each within the scatter of the next).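

In this assay, among these compounds, the change from 4-chlorophenyl to phenyl gives a 1.3-fold higher number from compound 1 to compound 3 (0.11 log units; within the scatter), the first direct reading of this position. On the core of compound 1, hydrogen can therefore replace chloro on this aromatic carbon with no difference that can be told from the scatter. Nothing available offers an explanation for this result.

On these data alone, whether a larger change at this place, such as an amine or a carboxylic acid, would move the number remains open. As far as these compounds go, it is also open whether chloro at this place would behave the same way on compound 2 .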